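Replacing bromo with nitro: what cytotoxicity to expect

This account rests on a few compounds, and the source may have more. Where it says the series, first, only, none or still open, it means among the compounds named here.

Compound 1 `CC(O)Cn1c([N+](=O)[O-])cnc1/C=C/c1ccccc1` gives 1500 nM in an ADME assay on cells (Macrophage, Homo sapiens) for cytotoxicity, read by MTT assay, with a stated time of 24 h; a higher number here means that more compound is tolerated, a lower number that less compound is tolerated.
Compound 2 `CC(O)Cn1c([N+](=O)[O-])cnc1/C=C/c1ccccc1F` gives 1410 nM in this assay.
Compound 3 `CC(O)Cn1c([N+](=O)[O-])cnc1/C=C/c1ccccc1Br` gives 490 nM in this assay.

Compound 3 holds the lowest of the three numbers. The step of a 1.1-fold lower number from compound 1 to compound 2 (0.03 log units; within the scatter) falls within the scatter, so compound 1 and compound 2 cannot be separated. The steps of a 3.1-fold lower number from compound 1 to compound 3 (0.49 log units; beyond the scatter) and a 2.9-fold lower number from compound 2 to compound 3 (0.46 log units; beyond the scatter) both lie beyond the scatter and set compound 3 apart as the one of which the least is tolerated.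

Compound 4 `CC(O)Cn1c([N+](=O)[O-])cnc1/C=C/c1ccccc1[N+](=O)[O-]` differs from compound 3 by nitro in place of bromo on an aromatic carbon. The two steps that reach compound 3 are the ones that bear on this change, since both alter the same aromatic carbon; yet neither involves a nitro group, so they only show that a change there has been either neutral (fluoro) or modestly lowering (bromo). Going by the values given here, with no direct precedent for nitro, compound 4 is expected to stay close to compound 3, with a step of a 1.4-fold higher number from compound 3 to compound 4 (0.15 log units; within the scatter) that does not clearly exceed the scatter. The estimate for compound 4 in this assay is 700 nM, with a range from 300 nM to 1800 nM.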

Compound 4, half-maximal cytotoxic concentration: 1090 nM
Beside the measured number, compound 4's estimate is 1.6-fold (0.19 log units) below it; low and high end bracket the measured number.
By their numbers in this assay, from the lowest: compound 3; then compounds 4, 2 and 1 (each within the scatter of the next).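

At this aromatic carbon, this assay now separates bromo from a further group, since the replacement gives a 2.2-fold higher number from compound 3 to compound 4 (0.35 log units; beyond the scatter). Against the other two compounds, a 1.3-fold lower number from compound 2 to compound 4 (0.11 log units; within the scatter) and a 1.4-fold lower number from compound 1 to compound 4 (0.14 log units; within the scatter) both stay within the scatter, so compound 4 cannot be told apart from compound 1 or compound 2. Among the four groups shown at this carbon, hydrogen, fluoro and nitro therefore form one set and only bromo, in compound 3, stands apart, so the lower number seen earlier belongs to that single group and not to every substitution at this place.

No measurement at hand offers an explanation for why bromo alone stands apart from the other three groups. From the compounds shown here alone, whether chloro, an amine, a carboxylic acid or a methoxy group on this same carbon would fall with bromo or with the other three remains open, as does whether the same groups would give the same picture on any other carbon of this aromatic ring.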